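A few compounds are considered here, and "the series" means these few. Any claim that something is new, unique, unknown or untested is made for them only; others in the source may bear on it.

Measured compounds:
- compound 1, `O=C(Cn1cc(CCCCO)nn1)NCc1ccccc1`, with 1700 uM in an ADME assay on cells (spleen, Mus musculus, strain C57BL/6) for inhibition, read by flow cytometry and propidium iodide staining, with a stated time of 24 h, at 37 degrees C; a lower number here means that less compound is needed, a higher number that more compound is needed for the effect
- compound 2, `CC(C)(O)c1cn(CC(=O)NCc2ccccc2)nn1`, with 1600 uM in this assay

The two compounds share the core of compound 1 and differ only in the group carried on the aromatic carbon. The step of a 1.1-fold lower number from compound 1 to compound 2 (0.03 log units; within the scatter) is within the scatter, so compound 2 and compound 1 are indistinguishable on the numbers available; compound 2 stands beside compound 1 rather than apart from it.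

Compound 3, `Cc1ccc(-c2cn(CC(=O)NCc3ccccc3)nn2)cc1`, has not been measured in this assay. It differs from compound 2 as follows: 4-methylphenyl in place of 1-hydroxy-1-methylethyl on an aromatic carbon. Going by the values given here, only one measured step bears on the change, and that step from compound 1 to compound 2 was within the scatter, while the group entering here is of another kind, a ring where an open chain stood. Among the compounds with values here, no measured step speaks for a shift beyond the scatter, so compound 3 is expected to give a number near that of compound 2, with wide uncertainty; the expected step is a 1.3-fold lower number from compound 2 to compound 3 (0.12 log units; within the scatter). The estimate for compound 3 is 1200 uM, with a range from 400 uM to 3000 uM.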

Compound 3, concentration for half-maximal effect: "non-toxic" (no number reported)
No number was reported for compound 3, so the estimate cannot be set against anything.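

In this assay, going by these compounds alone, compound 3 was reported only as "non-toxic", without a number, so no step from compound 2 to compound 3 can be read. No evidence bears on this result. The compounds shown leave open whether 4-methylphenyl in place of 1-hydroxy-1-methylethyl changes the number at all.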